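Hydroxy on the ring nitrogen of the most active compound

The source may hold more compounds than are shown below. What is called first, only, known or untested is meant among the compounds shown, and "the series" means these compounds.

The measured compounds and their values in a functional assay on HeLa cells (Homo sapiens) for antiproliferative activity, read by MTT assay, with a stated time of 48 h; on this read-out lower numbers stand for stronger inhibition and higher numbers for weaker inhibition:
Compound 1, `Cc1ccc(C(=O)Nc2ccc(Cl)cc2C(N)=O)cc1`, gives 8.23 ug/mL.
Compound 2, `Cc1ccc(-c2nc3ccc(Cl)cc3c(=O)[nH]2)cc1`, gives 10.1 ug/mL.
Compound 3, `Cc1ccc(-c2nc(N)c3cc(Cl)ccc3n2)cc1`, gives 3.56 ug/mL.

All three share a methyl-bearing phenyl ring joined to a chlorine-bearing core, and they differ in how that core is built. Among them compound 3 stands lowest, and both of its gaps, to compound 1 and to compound 2, lie beyond the usual scatter of this assay, so compound 3 is the most active of the three.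

Compound 4, `Cc1ccc(-c2nc(NO)c3cc(Cl)ccc3n2)cc1`, has not yet been measured. It differs from compound 3 in one place: hydroxy in place of hydrogen on a nitrogen on an aromatic ring. The nitrogen that carried two hydrogens in compound 3 now carries one hydrogen and one hydroxy group. Within the data shown here, no measured pair here shows what such a change does, so the expectation rests on the small size of the change alone and is loosely held.

For compound 4 the expectation is a step of a 1.3-fold higher number from compound 3 to compound 4 (0.10 log units; within the scatter), small and not clearly beyond the scatter in either direction. The estimate for compound 4 in this assay is 4.5 ug/mL, with a range from 1.5 ug/mL to 13 ug/mL.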

Compound 4, half-maximal inhibitory concentration: 12.7 ug/mL
Estimate against measurement, compound 4: 2.8-fold (0.45 log units) below; the measured number falls inside the stated range.
By their numbers in this assay, from the lowest: compound 3; then compounds 1, 2 and 4 (each within the scatter of the next).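

In this assay, replacing one hydrogen of the amino group on the aromatic ring with hydroxy, which turns amino into hydroxyamino, gives a 3.6-fold higher number from compound 3 to compound 4 (0.55 log units; beyond the scatter). Among these compounds, this is the first pair in the set that differs in only one place, and it shows that this nitrogen does not tolerate every small change: a single added oxygen moves the number beyond the usual scatter, towards weaker inhibition. Nothing available here accounts for this loss of activity, as no measurement of any property of these two compounds bears on it.

As far as these compounds go, it remains open whether any group on this nitrogen would bring a similar step or whether the effect is specific to hydroxy; a methyl group, a longer chain or an acetyl group in the same place would help tell these cases apart. Also open is what the methyl on the phenyl ring and the chlorine on the core contribute, since no pair among the compounds shown differs at either group.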